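Working notes on compound 4: a second fluoro enters

This account rests on a few compounds, and the source may have more. Where it says the series, first, only, none or still open, it means among the compounds named here.

Measured so far:
- compound 1 `Cn1nc(-c2ccccc2F)n(C)c1=S`: 0.74 mg/kg
- compound 2 `Cn1nc(-c2ccc(Cl)c(Cl)c2)n(C)c1=S`: 29 mg/kg
- compound 3 `Cn1nc(-c2ccccc2Cl)n(C)c1=S`: 0.37 mg/kg

In a functional assay on the whole organism with Mus musculus as the target (a lower number here means that less compound is needed, a higher number that more compound is needed for the effect), compound 1 stands second highest of the three numbers. Its nearest neighbour is compound 3 with 0.37 mg/kg, where a 2.0-fold lower number from compound 1 to compound 3 (0.30 log units; within the scatter). Furthest is compound 2 with 29 mg/kg, a gap beyond the scatter; no single-change step links compound 2 to compound 1, so its value is only read as what it is.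

Compound 4 `Cn1nc(-c2ccc(F)cc2F)n(C)c1=S` differs from compound 1 as follows: fluoro in place of hydrogen on an aromatic carbon. Among the compounds with values here, the only measured step, from compound 1 to compound 3, swaps halogens at the carbon already substituted and is within the scatter, so it bears only loosely on adding a group to an unsubstituted carbon. Compound 2, carrying two chloro groups elsewhere on the ring, gives a far higher number, which leaves some caution about substitution away from the position held in compound 1.

For compound 4 the expected number is 1.5 mg/kg (range 0.5 mg/kg to 6 mg/kg). The estimate implies a 2.0-fold higher number from compound 1 to compound 4 (0.31 log units; beyond the scatter), a modest shift, possibly within the scatter.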

Compound 4, dose for half-maximal effect: 1 mg/kg
Estimate against measurement, compound 4: 1.5-fold (0.18 log units) above, and the stated range covers the measured number.
By their numbers in this assay, from the lowest: compounds 3, 1 and 4 (each within the scatter of the next, the first and the last beyond it); then compound 2.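

In this assay fluoro in place of hydrogen on an aromatic carbon, meta to a fluoro group and para to a group of 8 heavy atoms, gives a 1.4-fold higher number from compound 1 to compound 4 (0.13 log units; within the scatter) and so leaves the number indistinguishable from that of compound 1. Within the data shown here, the earlier single-change step only exchanged one halogen for another at a carbon already substituted, so this is the first reading of a group added at a carbon that carried hydrogen. Nothing measured accompanies this result to explain it.

The compounds shown give this position only hydrogen and fluoro, so the outcome with chloro, a methoxy group, an amine or a carboxylic acid there stays open. Also open, going by these compounds, is whether the same fluoro would read alike on compound 3, which carries chloro in place of the first fluoro.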